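The source may hold more compounds than are shown below. What is called first, only, known or untested is meant among the compounds shown, and "the series" means these compounds.

Measured so far in a functional assay for inhibition, with Rattus norvegicus as the target; a higher number here means a weaker inhibitor, a lower number a stronger inhibitor:
compound 1 `CNc1nc(Cl)nc2c1ncn2[C@H]1CC(OP(=O)(O)O)[C@]2(CO)CC12` gives 29000 nM
compound 2 `CNc1nc(Cl)nc2c1ncn2CC(COC(=O)Oc1ccccc1)COC(=O)Oc1ccccc1` gives 26000 nM
compound 3 `CNc1nc(Cl)nc2c1ncn2C[C@@H](COP(=O)(O)O)OP(=O)(O)O` gives 1400 nM

Compound 1 stands at the highest of the three numbers in this assay. Its nearest neighbour is compound 2, whose number lies within the usual scatter of the number for compound 1, so the two cannot be told apart on these data. For the measured compounds named here, compound 3 lies well beyond the scatter from compound 1, with the lowest number of the set; no step between measured compounds is recorded, so only the two values themselves speak for that gap.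

The next compound, compound 4 `CNc1nc(Cl)nc2c1ncn2[C@H]1CC(OP(=O)(O)O)[C@]2(COC(C)=O)CC12`, follows from compound 1 by one change: acetyl in place of hydrogen on an oxygen on a saturated carbon. Everything else in compound 1 is kept. Going by the values given here, no measured pair in the set shows this same change, so there is no recorded step to lean on for its size.

On the available numbers the expectation for compound 4 is a small move, if any, toward a lower number, staying inside the usual scatter of the value for compound 1; the expected step is a 1.5-fold lower number from compound 1 to compound 4 (0.16 log units; within the scatter). Compound 4 is therefore estimated at 20000 nM in this assay, with a range from 7000 nM to 60000 nM.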

Compound 4, inhibition constant: 16000 nM
Estimate against measurement, compound 4: 1.3-fold (0.10 log units) above; the range from low to high includes it.
By their numbers in this assay, from the lowest: compound 3; then compounds 4, 2 and 1 (each within the scatter of the next).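

In this assay, the hydroxymethyl of compound 1 accepts an acetyl on its oxygen with a step that stays within the scatter, a 1.8-fold lower number from compound 1 to compound 4 (0.26 log units; within the scatter), so the two compounds cannot be told apart. For the compounds shown here, this is the first single-place step recorded, and it shows that at this oxygen on a saturated carbon the hydrogen of the hydroxy can give way to acetyl with no measurable consequence, while the rest of compound 1 is kept. Nothing measured here bears on what lies behind this result.

Going by these compounds, a single step with a single group gives no trend, so it remains open whether a longer chain on the ester such as butanoyl, a benzoyl, a methyl ether or an amine in place of the acetoxy would also stay within the scatter of compound 1. Going by these compounds alone, it also remains open whether the same hydroxy to acetoxy change would give a similarly small step on a different core, since no second pair shows it.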